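Methyl to Trifluoromethyl on the Shared Core

The compounds below may be only part of what the source reports. "The series", "measured", "known", "first", "only" and "open" are said of these compounds alone.

Three compounds sharing one core were tested in a functional assay on HepG2 cells (Homo sapiens) for inhibition, read by MTT assay, with a stated time of 72 h; on this read-out lower numbers stand for stronger inhibition and higher numbers for weaker inhibition. Compound 1 `CN(C(=O)NC(=O)c1ccc(Cl)cc1Cl)c1nc(C(F)(F)F)c(C(=O)N/N=C/c2cc(C(F)(F)F)cc(C(F)(F)F)c2)s1` gives only a limit of > 100 ug/mL in this assay. Compound 2 `CN(C(=O)NC(=O)c1cccc(C(F)(F)F)c1)c1nc(C(F)(F)F)c(C(=O)N/N=C/c2cc(C(F)(F)F)cc(C(F)(F)F)c2)s1` gives 5.38 ug/mL in this assay, and compound 3 `Cc1nc(N(C)C(=O)NC(=O)c2c(F)cccc2F)sc1C(=O)N/N=C/c1cc(C(F)(F)F)cc(C(F)(F)F)c1` gives 11.4 ug/mL. Going by the values given here, the single fully measured step, an at least 18-fold lower number from compound 1 to compound 2 (1.26 log units; beyond the scatter), concerns the aryl group on the carbonyl carbon. Compound 3 therefore holds the highest of the two numbers, with compound 2 nearest. Compound 1 sits at the limit (the limit of > 100 ug/mL in this assay, at which 1 of the 3 values shown sits). Compound 4 `CN(C(=O)NC(=O)c1c(F)cccc1F)c1nc(C(F)(F)F)c(C(=O)N/N=C/c2cc(C(F)(F)F)cc(C(F)(F)F)c2)s1` differs from compound 3 by trifluoromethyl in place of methyl on an aromatic carbon. Among the compounds with values here, no measured step touches this position, so no shift beyond the scatter is expected. Compound 4 is estimated at 9 ug/mL (range 3 ug/mL to 30 ug/mL), an expected step of a 1.3-fold lower number from compound 3 to compound 4 (0.10 log units; within the scatter).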

Compound 4, half-maximal inhibitory concentration: 6.28 ug/mL
Compound 4: the middle estimate sits 1.4-fold (0.16 log units) above what was measured; the measured number falls inside the stated range.
By their numbers in this assay, from the lowest: compounds 2, 4 and 3 (each within the scatter of the next, the first and the last beyond it). At a limit, above all of these: compound 1.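

On this aromatic carbon of the shared core, trifluoromethyl in place of methyl gives a 1.8-fold lower number from compound 3 to compound 4 (0.26 log units; within the scatter) in this assay, so this change moves the number by no more than the usual scatter. With trifluoromethyl held there, 2,6-difluorophenyl in place of 3-(trifluoromethyl)phenyl gives a 1.2-fold higher number from compound 2 to compound 4 (0.07 log units; within the scatter), whereas 2,6-difluorophenyl in place of 2,4-dichlorophenyl gives an at least 15-fold lower number from compound 1 to compound 4 (1.20 log units; beyond the scatter). Compound 1 stands at a limit, not at a measured number: the limit of > 100 ug/mL in this assay, at which 1 of the 4 values shown sits.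

Going by these compounds, whether an ethyl chain, an amine or a carboxylic acid on this aromatic carbon would shift the number beyond the scatter remains open. Also open, on these data alone, is whether 2,4-dichlorophenyl would give a limit with methyl at this position.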